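Isothiazolyl amide in place of the chloromethylphenyl anilide

This account rests on a few compounds, and the source may have more. Where it says the series, first, only, none or still open, it means among the compounds named here.

Compound 1 `COc1ccc(C(=O)Nc2c(C)cccc2Cl)cc1OC1CCCC1` is the reference point of this set. In an assay on isolated protein for inhibition of phosphodiesterase 4A (Sus scrofa) (a lower number here means a stronger inhibitor, a higher number a weaker inhibitor), compound 1 gives 100 nM, the lowest of the two numbers in hand. Compound 2 `COc1ccc(C(=O)Nc2c(F)cccc2F)cc1` gives 37000 nM in this assay, far beyond the scatter from compound 1. Compound 3 `COc1ccc(C(=O)Nc2ccccc2Cl)cc1OC(=O)c1ccccc1` returns only a limit in this assay, > 1000000 nM, which is not a number; it sits at the limit of > 1000000 nM in this assay, at which 1 of the 3 values shown sits. Among the measured compounds shown here, no two of these three differ in a single place, so no measured step is available. Compound 4 `COc1ccc(C(=O)Nc2c(C)nsc2C#N)cc1OC1CCCC1` differs from compound 1 by 5-cyano-3-methyl-1,2-thiazol-4-yl in place of 2-chloro-6-methylphenyl on an amide-type nitrogen. The expected step from compound 1 to compound 4 is a 1.7-fold lower number from compound 1 to compound 4 (0.22 log units; within the scatter), a small change within the scatter. Compound 4 is therefore estimated at 60 nM, in the range 10 nM to 400 nM.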

Compound 4, half-maximal inhibitory concentration: 200 nM
The estimate for compound 4 lay 3.3-fold (0.52 log units) below the measured number; the measured number falls inside the stated range.
By their numbers in this assay, from the lowest: compounds 1 and 4 (each within the scatter of the next); then compound 2. At a limit, above all of these: compound 3.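

Among the compounds shown here, the only measured single-place step falls on the amide-type nitrogen: 5-cyano-3-methyl-1,2-thiazol-4-yl in place of 2-chloro-6-methylphenyl gives a 2.0-fold higher number from compound 1 to compound 4 (0.30 log units; within the scatter) in this assay for this pair. This position therefore takes a five-membered aromatic ring with 2 hetero atoms in place of a six-membered aromatic ring of carbon only, with no change beyond the scatter. Nothing measured here gives a reason for this result.

The compounds shown leave open how much the nitrile contributes on this ring. A carboxylic acid or an amine in its place would test that directly.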